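Dropping the carboxymethoxy group from compound 1

The compounds below may be only part of what the source reports. "The series", "measured", "known", "first", "only" and "open" are said of these compounds alone.

Measured compounds in an ADME assay on Raji cells (Homo sapiens) for cytotoxicity, with a stated time of 72 h; a higher number here means that more compound is needed for the effect, a lower number that less compound is needed:
Compound 1 (`O=C(O)COc1cc(Cl)c(C(=O)Nc2cccc(-c3nc4ccccc4s3)c2)cc1[N+](=O)[O-]`): > 25000 nM (a limit)
Compound 2 (`O=C(Nc1nc2c(Cl)cccc2s1)c1cc([N+](=O)[O-])ccc1Cl`): 15000 nM (a number)
Compound 3 (`O=C(Nc1ccc(-c2nc3ccccc3s2)cc1)c1cc([N+](=O)[O-])ccc1Cl`): > 27000 nM (a limit)

Compound 1 stands at a limit, > 25000 nM and no number. Compound 3 also gives only a limit, > 27000 nM and no number. Compound 4 (`O=C(Nc1cccc(-c2nc3ccccc3s2)c1)c1cc([N+](=O)[O-])ccc1Cl`) comes from compound 1 by one change, hydrogen in place of carboxymethoxy on an aromatic carbon with hydrogen in place of carboxymethoxy on an aromatic carbon. Going by the values given here, no measured pair shows the size of such a change. Among the compounds with values here, compound 2 gives 15000 nM as the only number among the three, which suggests values of this order for compound 4. The expected step of a number no higher from compound 1 to compound 4 (the limit leaves the size open) in this assay is none beyond the usual scatter. For compound 4 the estimate is 25000 nM with an expected range of 11000 nM to 50000 nM and the reading may again be only a limit.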

Compound 4, half-maximal effective concentration in the Raji assay: > 27000 nM
Compound 4: only a limit was reported (the forecaster's own chance of this, stated with the estimate: 60%); middle value at least 1.0-fold (0.03 log units) away from the limit.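

In the Raji assay compound 1 gives only a limit, > 25000 nM. In the Raji assay compound 4 also gives only a limit, > 27000 nM. The step between them cannot be read. The compounds shown leave open whether hydrogen in place of carboxymethoxy changes the concentration needed for the effect at all. In a physicochemical assay for solubility, read by spectrophotometry, in phosphate buffer, measured as kinetic solubility, with a stated time of 18 h, at pH 7.4 (a higher number here means a more soluble compound, a lower number a less soluble compound), compound 1 gives 6700 nM and compound 4 gives 580 nM. In the physicochemical assay hydrogen in place of carboxymethoxy brings a 12-fold lower number from compound 1 to compound 4 (1.06 log units; beyond the scatter), a change in solubility that stands as measured: the measured solubility of compound 1, 6700 nM, and of compound 4, 580 nM, a 12-fold lower number (1.06 log units; beyond the scatter)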